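A few compounds are considered here, and "the series" means these few. Any claim that something is new, unique, unknown or untested is made for them only; others in the source may bear on it.

Compound 1 `FC(F)(F)c1ccc(CSc2nc(Sc3nnnn3-c3ccccc3)cc(C(F)(F)F)n2)cc1`: 12400 nM
Compound 2 `FC(F)(F)c1ccc(CSc2nc(Sc3nncs3)cc(C(F)(F)F)n2)cc1`: 10900 nM

Among the compounds with values here, in a functional assay on MGC-803 cells (Homo sapiens) for inhibition, read by MTT assay, with a stated time of 72 h (on this read-out higher numbers stand for weaker inhibition and lower numbers for stronger inhibition), compound 2 gives 10900 nM, level with compound 1, the only other compound measured. Compound 3 `Cc1nnc(Sc2cc(C(F)(F)F)nc(SCc3ccc(C(F)(F)F)cc3)n2)s1` follows from compound 2 by one change: methyl in place of hydrogen on an aromatic carbon. Within the data shown here, one measured step bears on this, and only loosely: a 1.1-fold lower number from compound 1 to compound 2 (0.06 log units; within the scatter). Among the measured compounds shown here, it replaced the whole group on the sulfur, yet the number stayed within the scatter, and no measured step tests a methyl. No shift beyond the scatter is therefore expected, and the estimated change is a 1.1-fold lower number from compound 2 to compound 3 (0.04 log units; within the scatter). Compound 3 is expected at 10000 nM, with a range of 4500 nM to 21000 nM.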

Compound 3, half-maximal inhibitory concentration: 11400 nM
Estimate against measurement, compound 3: 1.1-fold (0.06 log units) below; measured number inside the range.
By their numbers in this assay, from the lowest: compounds 2, 3 and 1 (each within the scatter of the next).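

In this assay the methyl gives a 1.0-fold higher number from compound 2 to compound 3 (0.02 log units; within the scatter), the first measured test of this aromatic carbon of the 1,3,4-thiadiazol-2-yl group. The 5-methyl-1,3,4-thiadiazol-2-yl group, set against 1-phenyl-1H-tetrazol-5-yl on the sulfur, gives a 1.1-fold lower number from compound 1 to compound 3 (0.04 log units; within the scatter), so this third group also leaves the number within the scatter. No measurement shown accounts for this lack of change. From the compounds shown here alone, whether an amine, a carboxylic acid or a longer chain on this carbon would move the number remains open. So does whether any change elsewhere on the shared core would do so.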